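A few compounds are considered here, and "the series" means these few. Any claim that something is new, unique, unknown or untested is made for them only; others in the source may bear on it.

Series notes. Compound 1 `Cc1ccc(S(=O)(=O)c2cnc3ccc(Cl)cc3c2N2CCC(C)CC2)cc1C` gives 84% in an assay on isolated protein for displacement of a labelled ligand from metabotropic glutamate receptor 5 (Homo sapiens), with a stated time of 60 min, tested at 1 uM; a higher number here means more inhibition at the concentration tested (going by the name of the read-out), a lower number less inhibition. For the measured compounds named here, compound 2 `CC1CCN(c2c(S(=O)(=O)c3cc(F)cc(F)c3)cnc3ccc(Cl)cc23)CC1` gives 93% in this assay; the single measured step, a number 9 percentage points higher from compound 1 to compound 2 (within the scatter), stays within the scatter. Compound 2 thus holds the higher of the two numbers, but its gap to compound 1 lies within the scatter, so no order between the two can be read from the data.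

Compound 3 `CC1CCN(c2c(S(=O)(=O)c3ccc(Cl)cc3)cnc3ccc(Cl)cc23)CC1` is not yet measured. It differs from compound 2 in one place: 4-chlorophenyl in place of 3,5-difluorophenyl on a sulfonyl sulfur. Going by the values given here, the only measured step that bears on this change is the earlier exchange of the aryl group on the sulfonyl sulfur, a number 9 percentage points higher from compound 1 to compound 2 (within the scatter), which moved the read-out within the scatter; both aryl groups tried on this sulfur so far gave high inhibition. The expected step in this assay is therefore a number 5 percentage points lower from compound 2 to compound 3 (within the scatter), none beyond the scatter. For compound 3 the estimate is 88%, with a range from 70% to 97%.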

Compound 3, a percentage reported as inhibition, at one concentration (the size of the read-out at that concentration, not a potency): 92%
Beside the measured number, compound 3's estimate is 4 percentage points below it; the measured number falls inside the stated range.
By their numbers in this assay, from the lowest: compounds 1, 3 and 2 (each within the scatter of the next).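

At the sulfonyl sulfur, 4-chlorophenyl joins 3,5-difluorophenyl and 3,4-dimethylphenyl as a third aryl group that leaves the read-out in this assay unresolved from the others: a number 1 percentage points lower from compound 2 to compound 3 (within the scatter), and a number 8 percentage points higher from compound 1 to compound 3 (within the scatter). For the compounds shown here, the earlier compounds offered only one such exchange, whereas these steps show that a chlorine-bearing phenyl also cannot be told apart from the fluorine-bearing and methyl-bearing phenyl groups in this read-out. No measurement in hand bears on why these aryl groups read alike.

Still open, on these data alone, is whether the read-out holds with an amine or a carboxylic acid on this phenyl ring, or with a benzyl group on the sulfonyl sulfur. As far as these compounds go, a percentage at one concentration gives only the size of the read-out at that concentration, so how compounds 1, 2 and 3 would compare at other concentrations also remains open.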